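This account rests on a few compounds, and the source may have more. Where it says the series, first, only, none or still open, it means among the compounds named here.

Measured compounds:
- compound 1, `CC(C)(C)c1cc2c(N/N=C\c3ccccn3)ncnc2s1`, 0.009 ug/mL
- compound 2, `Cc1cccc(/C=N\Nc2ncnc3sc(C(C)(C)C)cc23)n1`, 0.258 ug/mL

In a functional assay on PC-6 cells (Homo sapiens) for antiproliferative activity (on this read-out higher numbers stand for weaker inhibition and lower numbers for stronger inhibition), compound 2 holds the higher of the two numbers, and its nearest neighbour is compound 1, whose number is lower by a 29-fold higher number from compound 1 to compound 2 (1.46 log units; beyond the scatter), a step brought about by a methyl in place of hydrogen on an aromatic carbon. Compound 3, `CC(C)(C)c1cc2c(N/N=C\c3cccc(CN)n3)ncnc2s1`, differs from compound 2 by amino in place of hydrogen on a saturated chain carbon bound to an aromatic carbon. Among the compounds with values here, no measured step shows this change itself; the only step at hand, from compound 1 to compound 2, touches the same methyl position and was large, so this assay is sensitive there, but it gives no direction for the added amino. A step of modest size is therefore expected, with wide uncertainty, for compound 3, namely a 1.7-fold lower number from compound 2 to compound 3 (0.24 log units; within the scatter). Compound 3 is estimated at 0.15 ug/mL, ranging from 0.03 ug/mL to 0.8 ug/mL.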

Compound 3, half-maximal inhibitory concentration: 0.036 ug/mL
Compound 3: the middle estimate sits 4.2-fold (0.62 log units) above what was measured, and the stated range covers the measured number.
By their numbers in this assay, from the lowest: compound 1; then compound 3; then compound 2.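

In this assay the saturated chain carbon bound to an aromatic carbon proves able to take more than the methyl step alone suggested: amino in place of hydrogen there gives a 7.2-fold lower number from compound 2 to compound 3 (0.86 log units; beyond the scatter) and so wins back much of what the methyl had lost. The aminomethyl group still falls short of plain hydrogen on the aromatic carbon, with a 4.0-fold higher number from compound 1 to compound 3 (0.60 log units; beyond the scatter) and both steps lying beyond the scatter. Nothing at hand accounts for this recovery.

The compounds shown leave open whether the recovery belongs to the amine itself or would also appear with a hydroxymethyl group on the same position. They also leave open whether a dimethylaminomethyl group or a longer aminoethyl chain would bring the number closer to that of hydrogen.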